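A few compounds are considered here, and "the series" means these few. Any claim that something is new, unique, unknown or untested is made for them only; others in the source may bear on it.

Series notes. In an assay on a protein complex for inhibition of CDK8/Cyclin C (Homo sapiens), with a stated time of 1 h, tested at 10 uM (on this read-out lower numbers stand for less inhibition and higher numbers for more inhibition at the one concentration tested (going by the name of the read-out)), compound 1 `CC(C)[C@@H](NC(=O)/C=C/c1ccncc1-c1ccc2ccccc2c1)C(=O)O` gives 77%, the lowest of the three values recorded. Compound 2 `COc1ccc(-c2cnccc2/C=C/C(=O)N2CC(OC)C2)cc1OC` gives 87% in this assay, a number within the scatter of compound 1, so the two are not separated. Compound 3 `NNC(=O)CCc1ccncc1-c1ccc2ccccc2c1` gives 102% in this assay, which lies beyond the scatter above compound 1. Compound 4 `O=C(/C=C/c1ccncc1-c1ccc2ccccc2c1)N1CCOCC1` is not yet measured; it differs from compound 1 by morpholin-4-yl in place of (1-carboxy-2-methylpropyl)amino on a carbonyl carbon. For the measured compounds named here, no pair of measured compounds differs in one place, so the size of this change has no measured counterpart. Compound 2 gives 87% and compound 3 gives 102% with other groups on the carbonyl, so an upward step is anticipated. A step of a number 11 percentage points higher from compound 1 to compound 4 (beyond the scatter) is expected, near the edge of the scatter. Compound 4 is expected to give 88%, within 72% to 100%.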

Compound 4, a percentage reported as inhibition, at one concentration (the size of the read-out at that concentration, not a potency): 99%
For compound 4 the middle estimate is 11 percentage points below the measured one, and the stated range covers the measured number.
By their numbers in this assay, from the lowest: compounds 1 and 2 (each within the scatter of the next); then compounds 4 and 3 (each within the scatter of the next).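

On the carbonyl carbon whose other neighbour is the double-bonded chain carbon, morpholin-4-yl in place of (1-carboxy-2-methylpropyl)amino gives a number 22 percentage points higher from compound 1 to compound 4 (beyond the scatter) in this assay, the first measure of a single change at this position. The higher number comes with a group that has 0 hydrogen-bond donors and no defined stereocentre, so neither feature of the leaving group is required for this read-out. Nothing measured here accounts for the step.

From the compounds shown here alone, whether the step is particular to morpholin-4-yl, or would also appear with piperidin-1-yl or dimethylamino on the same carbonyl, remains open. A single-concentration read-out also leaves the potency of compound 4 open.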